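Working notes on the series, compound 4 pending

This account rests on a few compounds, and the source may have more. Where it says the series, first, only, none or still open, it means among the compounds named here.

Measured so far, in an assay on HEK293 cells for binding affinity to 5-hydroxytryptamine receptor 7 (Homo sapiens), read by radioligand binding; a higher number here means a weaker inhibitor, a lower number a stronger inhibitor:
compound 1 `CN1CCCN(CCn2ccc3ccc(C(F)(F)F)cc32)CC1` gives 23 nM
compound 2 `CN1CCCN(CCn2ccc3ccc(OCc4ccccc4)cc32)CC1` gives 182 nM
compound 3 `C=C(C)c1ccc2ccn(CCN3CCCN(C)CC3)c2c1` gives 70 nM

Compound 3 stands second highest of the three; its nearest neighbour is compound 2 (a 2.6-fold lower number from compound 2 to compound 3 (0.41 log units; beyond the scatter)), and the widest gap is a 3.0-fold higher number from compound 1 to compound 3 (0.48 log units; beyond the scatter). Compound 4 `CN1CCCN(CCn2ccc3ccc(-c4ccsc4)cc32)CC1` has not been measured. The change from compound 3 is thiophen-3-yl in place of 1-methylethenyl on an aromatic carbon. Going by the values given here, no measured step swaps one group for an aromatic group at this position, so only the overall spread, from a 7.9-fold higher number from compound 1 to compound 2 (0.90 log units; beyond the scatter) down to a 2.6-fold lower number from compound 2 to compound 3 (0.41 log units; beyond the scatter), frames the expectation: a modest step in this assay, direction uncertain, perhaps toward compound 2. The estimated step is a 1.1-fold higher number from compound 3 to compound 4 (0.06 log units; within the scatter). For compound 4 the estimate is 80 nM, within 25 nM to 250 nM.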

Compound 4, inhibition constant: 109 nM
Compound 4: middle estimate off by 1.4-fold (0.13 log units), on the low side; the range from low to high includes it.
By their numbers in this assay, from the lowest: compound 1; then compounds 3, 4 and 2 (each within the scatter of the next, the first and the last beyond it).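

In this assay, the first aromatic ring placed directly on this carbon lands within the scatter of both a small unsaturated group and a larger ether: thiophen-3-yl for 1-methylethenyl gives a 1.6-fold higher number from compound 3 to compound 4 (0.19 log units; within the scatter), and for benzyloxy gives a 1.7-fold lower number from compound 2 to compound 4 (0.22 log units; within the scatter). Trifluoromethyl stays apart, at a 4.7-fold higher number from compound 1 to compound 4 (0.68 log units; beyond the scatter), so compound 1 alone holds a number beyond the scatter of all three others. Nothing available gives a cause for this result.

Open, going by these compounds, is whether an amine, a carboxylic acid or a plain phenyl ring on this carbon would stay with compounds 2, 3 and 4 or move toward compound 1.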